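A Methyl Removed Twice on Two Related Cores

The compounds below may be only part of what the source reports. "The series", "measured", "known", "first", "only" and "open" are said of these compounds alone.

Of the compounds shown here, three have been measured in a functional assay on MGC-803 cells (Homo sapiens) for inhibition, read by sulforhodamine B assay; a higher number here means a weaker inhibitor, a lower number a stronger inhibitor. Compound 1, `O=C1C(Nc2ccccc2)=CC(=O)c2c1nc1n2[C@H]2OC[C@@H](O)[C@H]2OC1`, gives 1830 nM. Compound 2, `Cc1ccc(NC2=CC(=O)c3c(nc4n3[C@H]3OC[C@@H](O)[C@H]3OC4)C2=O)cc1`, carries a methyl on the aromatic ring that compound 1 lacks. In this assay compound 2 gives 1550 nM. Compound 3, `Cc1ccc(NC2=CC(=O)c3nc4n(c3C2=O)[C@H]2OC[C@@H](O)[C@H]2OC4)cc1`, is built from the same atoms as compound 2 joined differently; the difference between the two cores is not broken down here. In this assay compound 3 gives 1420 nM. The three numbers sit close together, and none of them can be called stronger or weaker than another.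

The change from compound 2 to compound 1 is hydrogen in place of methyl on an aromatic carbon. The step it made was a 1.2-fold higher number from compound 2 to compound 1 (0.07 log units; within the scatter).

Compound 4, `O=C1C=C(Nc2ccccc2)C(=O)c2c1nc1n2[C@H]2OC[C@@H](O)[C@H]2OC1`, has not yet been measured. It differs from compound 3 by hydrogen in place of methyl on an aromatic carbon. For the measured compounds named here, this is the same change as the one from compound 2 to compound 1, made at the same place on the aromatic ring, but on the core of compound 3 instead of that of compound 2.

Because compound 2 to compound 1 gave a 1.2-fold higher number from compound 2 to compound 1 (0.07 log units; within the scatter), and because compound 3 gives 1420 nM, the expected step from compound 3 to compound 4 is a 1.2-fold higher number from compound 3 to compound 4 (0.08 log units; within the scatter). The estimate for compound 4 in this assay is 1700 nM, expected to fall between 900 nM and 3300 nM.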

Compound 4, half-maximal inhibitory concentration: 1730 nM
The estimate for compound 4 lay 1.0-fold (0.01 log units) below the measured number, within the range that was stated.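

In this assay, replacing the methyl of compound 3 with hydrogen, which turns the 4-methylphenyl group into phenyl, gave a 1.2-fold higher number from compound 3 to compound 4 (0.09 log units; within the scatter). Set beside the same change on the other core, the two steps agree: the same change on two cores in this assay, a 1.2-fold higher number (0.07 log units; within the scatter) from compound 2 to compound 1 and a 1.2-fold higher number (0.09 log units; within the scatter) from compound 3 to compound 4, 1.0-fold (0.01 log units) apart, within the scatter of two such steps This shows that, for these two pairs, the swap carried from one core to the other without any readable difference, but both steps are so small that neither can be told apart from repeat-measurement noise, so it does not show that the methyl matters to the number on either core, and a match between two steps of this size is weak evidence that a larger step would transfer in the same way.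

The compounds shown leave open what happens when the methyl on this ring is replaced by something other than hydrogen, such as a chlorine atom, a methoxy group, an amine or a carboxylic acid. Only such a group, placed on both cores, could give a step large enough to test whether a change measured on one core can be relied on to predict the result on the other.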